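The source may hold more compounds than are shown below. What is called first, only, known or untested is meant among the compounds shown, and "the series" means these compounds.

Compound 1 `O=C(c1ccccn1)N1N=CCC1c1ccccc1`: 2.4
Compound 2 `CC(C)(C)C(=O)N1N=CCC1c1cc[nH]n1`: 2.7
Compound 3 `CN1CCC(C(=O)N2N=CCC2c2ccccc2)CC1`: 1.1

These values come from a physicochemical assay for lipophilicity, read by HPLC, measured as chromatographic lipophilicity, at pH 7.4; a lower number here means a more polar compound, a higher number a more lipophilic compound. Among the three, compound 1 stands second highest; compound 2 lies close to it, within the usual scatter, while compound 3 sits well below it, beyond the scatter. Compound 4 `O=C(C1CCOC1)N1N=CCC1c1ccccc1` has not yet been measured. It differs from compound 1 in one place: oxolan-3-yl in place of pyridin-2-yl on a carbonyl carbon. Within the data shown here, no measured pair shows this change, so its size is open. A six-membered aromatic ring with one hetero atom gives way to a five-membered non-aromatic ring with one hetero atom, and a modest downward step in this assay is expected, estimated at a number 0.40 log units lower from compound 1 to compound 4 (beyond the scatter). Compound 4 is accordingly expected to give about 2 in this assay, within a range of 1.4 to 2.6.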

Compound 4, distribution coefficient: 3
Compound 4: middle estimate off by 1.00 log units, on the low side; measured number outside the range, above it.
By their numbers in this assay, from the lowest: compound 3; then compounds 1, 2 and 4 (each within the scatter of the next, the first and the last beyond it).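

In this assay, oxolan-3-yl in place of pyridin-2-yl on a carbonyl carbon gives the first step read at this position (a number 0.60 log units higher from compound 1 to compound 4 (beyond the scatter)). The step appears although the hydrogen-bond donor and acceptor counts stay the same and neither group carries a net charge. No measurement shown accounts for it.

Still open, from the compounds shown here alone, is how much of the step belongs to the oxygen of oxolan-3-yl and how much to the ring itself. A cyclopentyl or phenyl group on the same carbonyl carbon would bear on that question.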